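Halo-exchange in the thiol acrylic acid series: compound 4

This account rests on a few compounds, and the source may have more. Where it says the series, first, only, none or still open, it means among the compounds named here.

Measured so far in an assay on isolated protein for inhibition of Calpain-1 catalytic subunit (Sus scrofa), read by FRET; a higher number here means a weaker inhibitor, a lower number a stronger inhibitor:
compound 1 `O=C(O)/C(S)=C/c1c[nH]c2cc(Cl)ccc12`: 210 nM
compound 2 `O=C(O)/C(S)=C/c1c[nH]c2c(F)cccc12`: 120 nM
compound 3 `O=C(O)/C(S)=C/c1c[nH]c2cc(F)ccc12`: 10 nM

Compound 2 and compound 1 give numbers within the scatter of each other, so nothing separates them. Against compound 3, compound 2 gives the higher number, and that gap lies beyond the scatter.

Compound 4 `O=C(O)/C(S)=C/c1c[nH]c2c(Br)cccc12` has not been measured in this assay. It differs from compound 2 by bromo in place of fluoro on an aromatic carbon.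

Among the compounds with values here, only one measured step exists, a 21-fold lower number from compound 1 to compound 3 (1.32 log units; beyond the scatter). That step exchanges one such substituent for another on an aromatic carbon, though at a different place on the shared core, and the smaller substituent went with the lower number. Within the data shown here, the change from compound 2 to compound 4 goes the other way, to a larger substituent, so in this assay a higher number is expected for compound 4, likely beyond the scatter, though the single measured step leaves the size uncertain.

For compound 4 an estimated value of 800 nM (range 200 nM to 3000 nM) is expected, which corresponds to an expected step of a 6.7-fold higher number from compound 2 to compound 4 (0.82 log units; beyond the scatter).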

Compound 4, half-maximal inhibitory concentration: 2 nM
For compound 4 the middle estimate is 400-fold (2.60 log units) above the measured one, outside the stated range (below it).
By their numbers in this assay, from the lowest: compound 4; then compound 3; then compounds 2 and 1 (each within the scatter of the next).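

On the aromatic carbon ortho to a fused ring and meta to a fused ring, bromo in place of fluoro gives, in this assay, a 60-fold lower number from compound 2 to compound 4 (1.78 log units; beyond the scatter); at this position, the exchange of one halogen for another can therefore move the number strongly downward, with bromo and not fluoro on the side of the lower number. The earlier exchange, a 21-fold lower number from compound 1 to compound 3 (1.32 log units; beyond the scatter), lies at a different place on the shared core and favours fluoro over chloro, so within these two pairs the halogen going with the lower number differs with place, although the pairs do not exchange the same two halogens and the direction of one step cannot be carried over to the other place. Nothing available explains this difference between the two places.

The compounds shown leave open how chloro or iodo would rank against bromo and fluoro at this position, and whether bromo would also give a low number at the place occupied by chloro in compound 1. They also leave open whether a methyl, methoxy or trifluoromethyl group at this position would follow bromo or fluoro.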